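Methyl for Fluoro on the Fused Ring of Compound 1

The source may hold more compounds than are shown below. What is called first, only, known or untested is meant among the compounds shown, and "the series" means these compounds.

Compound 1 `O=S(=O)(c1ccc(-c2cnc(C3CC3)o2)cc1)N1CCCOc2ccc(F)cc21` gives the lowest of the two numbers measured in a functional assay on PC-3 cells (Homo sapiens) for antiproliferative activity, read by MTT assay, with a stated time of 72 h (on this read-out lower numbers stand for stronger inhibition and higher numbers for weaker inhibition), at 18 nM. Compound 2 `O=[N+]([O-])c1ccc2c(c1)OCCCN2S(=O)(=O)c1ccc(-c2cnc(C3CC3)o2)cc1` gives 72 nM in this assay, a gap from compound 1 that lies beyond the usual scatter. Compound 3 `Cc1ccc2c(c1)N(S(=O)(=O)c1ccc(-c3cnc(C4CC4)o3)cc1)CCCO2` differs from compound 1 in one place: methyl in place of fluoro on an aromatic carbon. Among the compounds with values here, no measured pair covers this exchange, so the measured values give no direct guide to its size. Compound 3 is expected to stay close to compound 1, with a step of a 1.4-fold higher number from compound 1 to compound 3 (0.14 log units; within the scatter) not beyond the scatter. Compound 3 is estimated at 25 nM in this assay, within a range from 10 nM to 70 nM.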

Compound 3, half-maximal inhibitory concentration: 41 nM
Estimate against measurement, compound 3: 1.6-fold (0.21 log units) below; measured number inside the range.
By their numbers in this assay, from the lowest: compound 1; then compounds 3 and 2 (each within the scatter of the next).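

In this assay, within the data shown here, this aromatic carbon proves sensitive to the exchange: methyl in place of fluoro gives a 2.3-fold higher number from compound 1 to compound 3 (0.36 log units; beyond the scatter), the first measured step at this place, and a modest one. The number moves although the exchange leaves the heavy-atom count unchanged and neither group counts a hydrogen-bond donor or acceptor. Nothing available accounts for the step.

Open, on these data alone, is how a chloro, methoxy or amine group on this carbon would compare with fluoro and methyl. Also open, as far as these compounds go, is whether a hydroxyl or a longer chain would be tolerated there.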